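The compounds below may be only part of what the source reports. "The series", "measured", "known", "first", "only" and "open" are said of these compounds alone.

Measured so far in a functional assay on COLO 205 cells (Homo sapiens) for cytotoxicity, read by MTT assay, with a stated time of 24 h; a lower number here means a stronger inhibitor, a higher number a weaker inhibitor:
compound 1 `COc1cc2nc(Cl)nc(NS(=O)(=O)c3ccccc3)c2cc1OC` — 19 ug/mL
compound 2 `COc1cc2nc(N3CCCC3)nc(NS(=O)(=O)c3cccc(C(F)(F)F)c3)c2cc1OC` — 78 ug/mL
compound 3 `COc1ccc(S(=O)(=O)Nc2nc(Cl)nc3cc(OC)c(OC)cc23)cc1C` — 57 ug/mL

Compound 1 gives the lowest number of the three. Compound 3 is nearest to it, a 3.0-fold higher number from compound 1 to compound 3 (0.48 log units; beyond the scatter). Among the measured compounds shown here, compound 2 differs from compound 1 in two places and gives a higher number still; no single step joins them.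

The unmeasured compound 4 `COc1cc2nc(Cl)nc(NS(=O)(=O)c3cccs3)c2cc1OC` differs from compound 1 in one place: thiophen-2-yl in place of phenyl on a sulfonyl sulfur. For the measured compounds named here, the only measured single step in this set, a 3.0-fold higher number from compound 1 to compound 3 (0.48 log units; beyond the scatter), put 4-methoxy-3-methylphenyl in place of phenyl on the sulfonyl sulfur and gave a higher number. Going by the values given here, it is not an exchange of phenyl for thiophen-2-yl, so no measured step bears directly on compound 4. What the data do show is that altering the group on the sulfonyl sulfur moved the number by a modest amount, not a large one. Compound 4 is therefore expected to land close to compound 1, with the estimated step of a 1.3-fold higher number from compound 1 to compound 4 (0.12 log units; within the scatter) likely to stay within the scatter. The estimate for compound 4 in this assay is 25 ug/mL, with a range of 10 ug/mL to 60 ug/mL.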

Compound 4, half-maximal inhibitory concentration: 27.5 ug/mL
For compound 4 the middle estimate is 1.1-fold (0.04 log units) below the measured one; the range from low to high includes it.
By their numbers in this assay, from the lowest: compounds 1 and 4 (each within the scatter of the next); then compounds 3 and 2 (each within the scatter of the next).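

Read in this assay, the group on the sulfonyl sulfur need not be a six-membered aromatic ring of carbon only: a five-membered aromatic ring with a sulfur atom fits there, and thiophen-2-yl in place of phenyl gives a 1.4-fold higher number from compound 1 to compound 4 (0.16 log units; within the scatter). Thiophen-2-yl in place of 4-methoxy-3-methylphenyl gives a 2.1-fold lower number from compound 3 to compound 4 (0.32 log units; beyond the scatter), so among the three groups compared at this place, 4-methoxy-3-methylphenyl alone stands apart, with a step beyond the scatter to each of the other two. Nothing on hand accounts for either step.

From the compounds shown here alone, whether an aromatic ring is needed on the sulfonyl sulfur at all remains open, as a methyl or a cyclohexyl group there would test. Also open, going by these compounds, is whether thiophen-2-yl and phenyl stay within the scatter of each other once the chlorine of the shared core gives way to a group such as morpholine.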